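The source may report more compounds than this note shows. Statements on the series, on what has been measured and on what is new or still open speak of the compounds shown alone.

In a functional assay on cells (LY3.7.2C TK-/- cell line, Mus musculus) (on this read-out lower numbers stand for stronger inhibition and higher numbers for weaker inhibition), compound 1 (`Cc1ccc2nc(N)nc(O)c2c1Sc1ccc(C(=O)N[C@H](C(=O)O)c2ccccc2)cc1`) gives 800 nM and compound 2 (`Cc1ccc2nc(N)nc(O)c2c1Sc1ccc(C(=O)N[C@H](C(=O)O)c2cccc(O)c2)cc1`) gives 600 nM. Within the data shown here, these are the only two numbers available, and they cannot be told apart. Compound 3 (`Cc1ccc2nc(N)nc(O)c2c1Sc1ccc(C(=O)N[C@H](C(=O)O)c2cccc(C(=O)O)c2)cc1`) has not yet been measured. It differs from compound 1 by carboxy in place of hydrogen on an aromatic carbon, meta to a large group: carboxy in place of hydrogen on an aromatic carbon. Among the measured compounds shown here, only one measured step bears on this change, a 1.3-fold lower number from compound 1 to compound 2 (0.12 log units; within the scatter), which also replaces hydrogen on an aromatic carbon, but with hydroxy. For the measured compounds named here, that single step, made with a different group, is a weak guide, and no carboxy compound has yet been measured here. No step beyond the scatter is therefore expected in this assay, and the expected step is a 1.1-fold higher number from compound 1 to compound 3 (0.05 log units; within the scatter). For compound 3 the estimated value is 900 nM, with an expected range of 280 nM to 3500 nM.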

Compound 3, half-maximal inhibitory concentration: 700 nM
Compound 3: middle estimate off by 1.3-fold (0.11 log units), on the high side, and the stated range covers the measured number.
By their numbers in this assay, from the lowest: compounds 2, 3 and 1 (each within the scatter of the next).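

Among these compounds, putting carboxy on this aromatic carbon, meta to a large group, gives a 1.1-fold lower number from compound 1 to compound 3 (0.06 log units; within the scatter) in this assay, the first measurement of a group that brings a carbonyl to this place. Exchanging hydroxy for carboxy at the same place gives a 1.2-fold higher number from compound 2 to compound 3 (0.07 log units; within the scatter), so in this assay phenyl, the hydroxy compound and 3-carboxyphenyl now form a set of three that cannot be told apart, and two quite different groups have left the number within the scatter of hydrogen. Nothing measured here explains why the number holds across these groups.

The compounds shown leave open whether an amine, a methyl ester or a longer chain at this place would also stay within the scatter. They also leave open whether carboxy would behave the same way on another carbon of this ring.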